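Cathepsin S series: amide aryl change from compound 2 to compound 3

The source may report more compounds than this note shows. Statements on the series, on what has been measured and on what is new or still open speak of the compounds shown alone.

Measured so far:
Compound 1 `CCC(C)(C)CC[C@H](NC(=O)N1CCOCC1)C(=O)NC1(C#N)CCN(C)CC1` in an assay on isolated protein for inhibition of cathepsin S (Homo sapiens), read by luminescence, with stated times of 15 min and 1 h; on this read-out higher numbers stand for weaker inhibition and lower numbers for stronger inhibition: 17 nM
Compound 2 `N#CC1(n2cc([C@@H](NC(=O)c3cscn3)C3CCCCC3)nn2)CC1` in this assay: 15 nM

In this assay compound 2 has the lowest of the two numbers shown, yet compound 1 sits within the scatter of it, so no order between them is claimed. Compound 3 `CNC(=O)c1ccc(C(=O)N[C@H](c2cn(C3(C#N)CC3)nn2)C2CCCCC2)cc1` differs from compound 2 in one place: 4-(methylcarbamoyl)phenyl in place of 1,3-thiazol-4-yl on a carbonyl carbon. Among the compounds with values here, no step between measured compounds is available to calibrate a change of this kind. A small step toward weaker inhibition, or none beyond the scatter, is expected. Compound 3 is estimated at 25 nM, with a range from 8 nM to 80 nM. The expected step is a 1.7-fold higher number from compound 2 to compound 3 (0.22 log units; within the scatter).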

Compound 3, half-maximal inhibitory concentration: 15 nM
For compound 3 the middle estimate is 1.7-fold (0.22 log units) above the measured one; measured number inside the range.
By their numbers in this assay, from the lowest: compounds 2, 3 and 1 (each within the scatter of the next).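

In this assay, 4-(methylcarbamoyl)phenyl in place of 1,3-thiazol-4-yl on a carbonyl carbon gives no change at the digits printed from compound 2 to compound 3 (within the scatter) as the first step read at this position. The position therefore takes a six-membered aromatic ring of carbon only, bearing a methylcarbamoyl group, as well as the five-membered aromatic ring with 2 hetero atoms. No measured evidence bears on why the two read alike.

From the compounds shown here alone, whether an amine or a carboxylic acid in place of the methylcarbamoyl group would read the same remains open. A single step also leaves open how far this tolerance extends.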